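Trifluoromethyl on compound 1: expected tolerance in cell culture

The compounds below may be only part of what the source reports. "The series", "measured", "known", "first", "only" and "open" are said of these compounds alone.

compound 1 `Brc1ccc(NCc2cn(-c3ccccc3)nc2-c2ccccc2)cc1` gives > 100000 nM
compound 2 `Clc1ccc(NCc2cn(-c3ccccc3)nc2-c2ccc(Cl)cc2)cc1` gives > 100000 nM
compound 3 `Cc1ccc(-c2nn(-c3ccccc3)cc2CNc2ccc(Cl)cc2)cc1` gives > 100000 nM

In an ADME assay on MDBK cells (Bos taurus) for cytotoxicity, read by MTT assay, with a stated time of 72 h (a lower number here means that less compound is tolerated, a higher number that more compound is tolerated), compound 1 gives > 100000 nM as a limit and not a number. For the measured compounds named here, compound 2 and compound 3 also give limits, so no measured compound has a number to its name.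

Compound 4 `FC(F)(F)c1ccc(-c2nn(-c3ccccc3)cc2CNc2ccc(Br)cc2)cc1` departs from compound 1 by trifluoromethyl in place of hydrogen on an aromatic carbon and this reads as phenyl to 4-(trifluoromethyl)phenyl, para to a large group. Going by the values given here, the only measured step is a step that the two limits leave unreadable from compound 2 to compound 3 and it puts methyl in place of chloro on an aromatic carbon. It offers no size to carry over.

The expectation for compound 4 rests on compound 1, compound 2 and compound 3 together, which stand at the limit of > 100000 nM in this assay, at which 3 of the 3 values shown sit, and nothing more. No step beyond the scatter is expected in this assay in either direction, and the expected step is a number no higher from compound 1 to compound 4 (the limit leaves the size open) on that basis. For compound 4 the estimate is 100000 nM with an expected range from 50000 nM to 200000 nM and a report as a limit is the likely outcome.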

Compound 4, half-maximal cytotoxic concentration: 64000 nM
Beside the measured number, compound 4's estimate is 1.6-fold (0.19 log units) above it, and the stated range covers the measured number.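

In this assay, for the compounds shown here, trifluoromethyl on the phenyl ring, para to a large group, yields the first actual number, with an at least 1.5-fold lower number from compound 1 to compound 4 (0.19 log units; that floor lies within the scatter). The step rests on a limit for compound 1, so it gives only a floor, and that floor does not show a real loss of tolerance. What is new is that this position accepts phenyl to 4-(trifluoromethyl)phenyl with a readable value, and compound 4 is the only compound shown that has one: the limit of > 100000 nM in this assay, at which 3 of the 4 values shown sit.

Going by these compounds, the true size of the step remains open, as does any comparison with the other compounds, whose values are limits. On these data alone, it is also open whether an amine or a carboxylic acid at this position would give a step clearly beyond the scatter.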